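The compounds below may be only part of what the source reports. "The series", "measured", "known", "first", "only" and "open" are said of these compounds alone.

Compound 2 `O=C(/C=C/c1ccc(O)cc1)c1c(O)cccc1OCC1CCCCC1` is the starting point of this step. In a functional assay on NCI-H23 cells (Homo sapiens) for antiproliferative activity, read by sulforhodamine B assay (a lower number here means a stronger inhibitor of growth, a higher number a weaker inhibitor of growth), compound 2 gives > 30000 nM, which is a limit of the assay rather than a number. Two related compounds have been measured beside it. Compound 1 `CCCCCCOc1cccc(O)c1C(=O)/C=C/c1ccc(O)cc1` carries a pentyl on the saturated chain carbon bound to an oxygen on an aromatic ring, where compound 2 carries a cyclohexyl; in this assay compound 1 gives > 30000 nM, again a limit. Compound 3 `COc1cccc(OCCC(C)(C)C)c1C(=O)/C=C/c1ccc(O)cc1` gives > 30000 nM in this assay, also a limit. For the measured compounds named here, the single step between measured compounds that differ in one place, a step that the two limits leave unreadable from compound 1 to compound 2, cannot be read in size because both of its ends sit at the limit of > 30000 nM in this assay, at which 3 of the 3 values shown sit.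

Compound 4 `O=C(/C=C/c1ccc(O)cc1)c1c(O)cccc1OCc1ccccc1` has not yet been measured. It differs from compound 2 by phenyl in place of cyclohexyl on a saturated chain carbon bound to an oxygen on an aromatic ring; cut one bond further out, the change reads cyclohexylmethoxy to benzyloxy. Going by the values given here, no measured step speaks to this exchange, and the only firm fact is the limit of > 30000 nM in this assay, at which 3 of the 3 values shown sit, where every value so far rests. Compound 4 is therefore expected to give about 40000 nM in this assay, within a range from 8000 nM to 150000 nM. The expected step that the limit leaves unreadable from compound 2 to compound 4 is estimated to be none beyond the scatter, with a strong chance that only a limit is reported again.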

Compound 4, concentration for 50% growth inhibition: > 30000 nM
Compound 4 gave a limit, no number; the forecaster's own chance of this, stated with the estimate: 75%; the middle value lies beyond the limit too.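

In this assay compound 4 stays at a limit, as do compound 1 and compound 2, so no step among these three compounds can be read in size: the limit of > 30000 nM in this assay, at which 4 of the 4 values shown sit. The compounds shown leave open whether pentyl, cyclohexyl and phenyl differ at all in this place, and what change to the shared core would bring a measurable number.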